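This account rests on a few compounds, and the source may have more. Where it says the series, first, only, none or still open, it means among the compounds named here.

In an in vivo ADME assay on the whole organism for pharmacokinetics, with Rattus norvegicus as the target (a higher number here means faster removal of the compound, a lower number slower removal), compound 3 (`CS(=O)(=O)Nc1ccc(C(=O)Nc2ccc(Cl)c(-c3ccccn3)c2)c(Cl)c1`) gives 2.4 mL/min/kg and stays within the scatter of compound 1 (`O=C(Nc1ccc(Cl)c(-c2ccccn2)c1)c1ccc(-n2cncn2)nc1`), which gives 4 mL/min/kg in the same measurement. Going by the values given here, compound 2 (`CS(=O)(=O)Cc1ccc(C(=O)Nc2ccc(Cl)c(-c3ccccn3)c2)c(Cl)c1`) gives 5.5 mL/min/kg and is the only compound clearly apart from compound 3.

The change under review leads from compound 3 to compound 4 (`O=C(NCc1ccccn1)c1ccc(C(=O)Nc2ccc(Cl)c(-c3ccccn3)c2)c(Cl)c1`). It puts ((pyridin-2-yl)methyl)carbamoyl in place of methanesulfonamido on an aromatic carbon, meta to a chloro group and para to a large group (((pyridin-2-yl)methyl)carbamoyl in place of methanesulfonamido on an aromatic carbon).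

One measured step involves the leaving group: a 2.3-fold lower number from compound 2 to compound 3 (0.36 log units; beyond the scatter) with methanesulfonamido in place of (methylsulfonyl)methyl. That step is modest. Read in reverse, it shows a higher number when methanesulfonamido is absent. Among the compounds with values here, no measured compound carries the entering group, so the size of the step rests on this single comparison and remains uncertain. A modest step towards faster removal is the working expectation, of about the same size as the one measured. The estimated change is a 2.1-fold higher number from compound 3 to compound 4 (0.32 log units; beyond the scatter) and a much larger step is not expected. For compound 4 the estimated clearance is 5 mL/min/kg with 2 mL/min/kg to 12 mL/min/kg as the expected range.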

Compound 4, clearance: 6.7 mL/min/kg
The estimate for compound 4 lay 1.3-fold (0.13 log units) below the measured number, within the range that was stated.
By their numbers in this assay, from the lowest: compounds 3, 1, 2 and 4 (each within the scatter of the next, the first and the last beyond it).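

At this aromatic carbon, meta to a chloro group and para to a large group, this assay now has a reading for a substituent carrying a six-membered aromatic ring: ((pyridin-2-yl)methyl)carbamoyl in place of methanesulfonamido gives a 2.8-fold higher number from compound 3 to compound 4 (0.45 log units; beyond the scatter), so the low number of compound 3 does not carry over to this larger group, even though the two groups have equal counts of hydrogen-bond donors and acceptors. Set against (methylsulfonyl)methyl, the same group gives a 1.2-fold higher number from compound 2 to compound 4 (0.09 log units; within the scatter), which leaves compound 2 and compound 4 together and methanesulfonamido as the only one of the three groups at this place that stands apart. No available measurement accounts for the position of methanesulfonamido or for the shift with the entering group.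

Open, from the compounds shown here alone, is whether the number at this place follows the carbamoyl link or the pyridine ring of the entering group, a question that a plain carbamoyl or a benzylcarbamoyl group would help to separate. Also open, going by these compounds, is whether an acetamido group, which keeps the nitrogen link without the sulfonyl, would sit with compound 3 or with compound 2 and compound 4.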